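The compounds below may be only part of what the source reports. "The series", "measured", "known", "first", "only" and "open" are said of these compounds alone.

Measured compounds in a functional assay on OVCAR-3 cells (Homo sapiens) for cytotoxicity, read by sulforhodamine B assay, with a stated time of 48 h; a higher number here means a weaker inhibitor of growth, a lower number a stronger inhibitor of growth:
- compound 1, `Nc1nc(Cl)c2ncn(Cc3ccccc3CCl)c2n1`: 3390 nM
- compound 2, `Nc1nc(Cl)c2ncn(Cc3cccc(CCl)c3)c2n1`: 720 nM
- compound 3, `ClCc1ccc(Cn2cnc3ncnc(Cl)c32)cc1`: 1810 nM

Compound 3 holds the second highest of the three numbers. Its nearest neighbour is compound 1, whose number is higher but still within the scatter, so the two cannot be ordered on these figures. Compound 2 gives the lowest number of the set and lies beyond the scatter from compound 3, so compound 2 is the stronger growth inhibitor of that pair.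

The next compound, compound 4, `ClCc1ccc(Cn2cnc3nc(Cl)nc(Cl)c32)cc1`, is not yet measured. It differs from compound 3 in one place: chloro in place of hydrogen on an aromatic carbon. For the measured compounds named here, the rest of the molecule is unchanged, and no measured pair in this set shows this kind of change, so there is no step on record to lean on.

With nothing comparable measured, the working expectation is a small effect: the step of a 1.2-fold lower number from compound 3 to compound 4 (0.08 log units; within the scatter) is estimated to stay within the usual scatter, with no firm direction. Compound 4 is therefore expected to give about 1500 nM in this assay, with a plausible range from 500 nM to 4500 nM.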

Compound 4, concentration for 50% growth inhibition: 300 nM
Compound 4: middle estimate off by 5.0-fold (0.70 log units), on the high side; measured number below the stated range.
By their numbers in this assay, from the lowest: compound 4; then compound 2; then compounds 3 and 1 (each within the scatter of the next).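

In this assay, chloro in place of hydrogen on the aromatic carbon between two ring nitrogen atoms gives a 6.0-fold lower number from compound 3 to compound 4 (0.78 log units; beyond the scatter) with the rest of the molecule unchanged. For the compounds shown here, this is the first one-place change, and it shows that this position is not silent: a single added chlorine is enough to move the number beyond the scatter, towards stronger growth inhibition. No measurement at hand bears on why the step has this direction or size.

From the compounds shown here alone, the step rests on a single pair, and compounds 1 and 2 differ from compound 4 in more than one place, so it remains open whether the same change would act alike with the chloromethyl group placed differently in the molecule. Also open, going by these compounds, is whether the effect is specific to chloro or would also appear with fluoro, a methyl group or a methoxy group on the same aromatic carbon.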